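The compounds below may be only part of what the source reports. "The series", "measured", "known", "first", "only" and "open" are said of these compounds alone.

Measured so far:
Compound 1 `C=CC(=O)Nc1cc(Nc2nc(C)cc(-c3cn(C)c4ccccc34)n2)c(OC)cc1N(C)CCN(C)C` — in a functional assay on HepG2 cells (Homo sapiens) for antiproliferative activity, read by MTT assay, with a stated time of 72 h (a higher number here means a weaker inhibitor, a lower number a stronger inhibitor), compound 1 gives 12600 nM.
Compound 2 `CC/C=C\C(=O)Nc1cc(Nc2nc(C)cc(-c3cn(C)c4ccccc34)n2)c(OC)cc1N(C)CCN(C)C` — in this assay compound 2 gives 2050 nM.

Compound 1 has the highest of these two numbers; its nearest neighbour is compound 2, reached by a 6.1-fold lower number from compound 1 to compound 2 (0.79 log units; beyond the scatter). Compound 3 `C=CC(=O)Nc1cc(Nc2nc(C)cc(-c3cn(C)c4ccc(F)cc34)n2)c(OC)cc1N(C)CCN(C)C` differs from compound 1 by fluoro in place of hydrogen on an aromatic carbon. Within the data shown here, the only measured step, from compound 1 to compound 2, alters the group on the carbonyl carbon, not the fused ring, so no measured step bears on this change. The expected step is therefore none beyond the scatter, a 1.3-fold lower number from compound 1 to compound 3 (0.10 log units; within the scatter). Compound 3 is estimated at 10000 nM, within 3500 nM to 30000 nM.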

Compound 3, half-maximal inhibitory concentration: 4280 nM
The estimate for compound 3 lay 2.3-fold (0.37 log units) above the measured number; measured number inside the range.
By their numbers in this assay, from the lowest: compound 2; then compound 3; then compound 1.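

In this assay fluoro in place of hydrogen gives a 2.9-fold lower number from compound 1 to compound 3 (0.47 log units; beyond the scatter) and so shows that the six-membered aromatic ring of the fused system, unchanged until now, can also shift the number. The earlier step changed only the group on the carbonyl carbon, so a second place in the molecule now matters. Nothing available explains why this small change lowers the number. Still open, going by these compounds, is whether chloro or methoxy on the same carbon would act like fluoro, and whether fluoro would also lower the number when combined with the but-1-en-1-yl group of compound 2.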